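The source may report more compounds than this note shows. Statements on the series, on what has been measured and on what is new or still open speak of the compounds shown alone.

Measured so far in an ADME assay on microsomes from liver (Mus musculus) for metabolic stability, read by LC-MS, with NADPH named in the record, with a stated time of 60 min, tested at 1 uM, in the absence of a further agent; a lower number here means that less of the compound is left, a higher number that more of the compound is left:
- compound 1 `COc1ccc(-c2scc3c(N4CC[C@@H](NC(C)=O)C4)nc(C)nc23)cc1OC`: > 95%
- compound 2 `CC(=O)N[C@@H]1CCN(c2cc(C)nn3c(-c4ccc(C#N)cc4)c(C)nc23)C1`: > 95%
- compound 3 `COc1ccc(-c2c(C)nc3c(N4CC[C@@H](NC(=O)c5ccccc5)C4)cc(C)nn23)cc1OC`: > 95%

Compound 3 gives > 95%, and this is a limit of the assay, not a number. The same holds across the set: the limit of > 95% in this assay, at which 3 of the 3 values shown sit. Compound 1 and compound 2 therefore cannot be ranked against compound 3 in this assay.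

Compound 4 `COc1ccc(-c2c(C)nc3c(N4CC[C@@H](NC(=O)COc5ccccc5)C4)cc(C)nn23)cc1OC` changes compound 3 in one place, with phenoxymethyl in place of phenyl on a carbonyl carbon. Cut one bond further out, this reads benzamido to ((phenoxymethyl)carbonyl)amino.

For the measured compounds named here, no measured pair differs in one place only, so this change has no direct precedent here. The estimate rests on the three compounds that share the limit and on the size of the change. No step beyond the scatter is expected, and any movement is expected to be downward. The expected step is a number at least 5 percentage points lower from compound 3 to compound 4 (that floor lies within the scatter). For compound 4 the estimated value is 90%, with an expected range of 70% to 100%.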

Compound 4, percent of the compound remaining: > 95%
Compound 4 was reported as a limit (the forecaster's own chance of this, stated with the estimate: 50%); middle value at least 5 percentage points away from the limit.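

No step can be read from compound 3 to compound 4, since both values in this assay are limits of the assay, not numbers: the limit of > 95% in this assay, at which 4 of the 4 values shown sit.

The compounds shown leave open how much of any compound remains and whether phenoxymethyl in place of phenyl on a carbonyl carbon changes that amount at all.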